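Amide Aryl Swap on a Shared Core

The source may report more compounds than this note shows. Statements on the series, on what has been measured and on what is new or still open speak of the compounds shown alone.

Compound 1 `COc1ccc(C(=O)Nc2cccc(-c3oc4cc(-c5ccc(F)cc5)ccc4c(=O)c3O)c2)cc1`: 8700 nM
Compound 2 `Cc1ccccc1C(=O)Nc1cccc(-c2oc3cc(-c4ccc(F)cc4)ccc3c(=O)c2O)c1`: 17600 nM
Compound 3 `COc1ccc(C(=O)Nc2cccc(-c3oc4cc(-c5ccc(F)cc5)ccc4c(=O)c3O)c2)c(F)c1`: 40000 nM

In a functional assay on A549 cells (Homo sapiens) for antiproliferative activity, read by CCK-8 assay, with a stated time of 72 h (a higher number here means a weaker inhibitor, a lower number a stronger inhibitor), compound 3 stands highest of the three numbers; compound 2 is nearest and compound 1 furthest from it. Compound 4 `Cc1cc(C)cc(C(=O)Nc2cccc(-c3oc4cc(-c5ccc(F)cc5)ccc4c(=O)c3O)c2)c1` differs from compound 3 in one place: 3,5-dimethylphenyl in place of 2-fluoro-4-methoxyphenyl on a carbonyl carbon. Within the data shown here, two measured steps bear on this change. The step of a 2.3-fold higher number from compound 2 to compound 3 (0.36 log units; beyond the scatter) shows what the exchange of a methylphenyl for the fluoro-methoxy group did, and a 4.6-fold higher number from compound 1 to compound 3 (0.66 log units; beyond the scatter) shows the weight of the fluoro alone. Both point to a lower number once the fluoro and methoxy groups leave and methyl groups enter, so a modest step downward is expected, a 2.2-fold lower number from compound 3 to compound 4 (0.35 log units; beyond the scatter). Compound 4 is therefore estimated at 18000 nM, within a range of 7000 nM to 45000 nM.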

Compound 4, half-maximal inhibitory concentration: 3740 nM
Estimate against measurement, compound 4: 4.8-fold (0.68 log units) above; measured number below the stated range.
By their numbers in this assay, from the lowest: compound 4; then compound 1; then compound 2; then compound 3.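

In this assay, among these compounds, the 3,5-dimethylphenyl group gives the lowest of the four numbers, with an 11-fold lower number from compound 3 to compound 4 (1.03 log units; beyond the scatter) and a 4.7-fold lower number from compound 2 to compound 4 (0.67 log units; beyond the scatter) and a 2.3-fold lower number from compound 1 to compound 4 (0.37 log units; beyond the scatter) showing that this position on the carbonyl carbon has a wider span than the earlier compounds revealed. Methyl groups do not lower the number in every case, since compound 2, with its 2-methylphenyl group, stands above compound 1. No measurement shown here explains this order. As far as these compounds go, whether an amine, a carboxylic acid or a longer chain on this aryl ring would lower the number further remains open.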